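This account rests on a few compounds, and the source may have more. Where it says the series, first, only, none or still open, it means among the compounds named here.

Measured so far in a physicochemical assay for solubility; on this read-out lower numbers stand for lower solubility and higher numbers for higher solubility:
compound 1 `COCCCn1c(=O)[nH]c2c(N)nc(C(F)(F)F)cc21` – 23 ug/mL
compound 2 `Cc1ccc(Cn2c(=O)[nH]c3c(N)nc(C(F)(F)F)cc32)nc1` – 3 ug/mL

Compound 1 holds the higher of the two numbers; the nearest, compound 2, sits a 7.7-fold lower number from compound 1 to compound 2 (0.88 log units; beyond the scatter) below it. Compound 3 `Cc1nc(Cn2c(=O)[nH]c3c(N)nc(C(F)(F)F)cc32)cs1` is not yet measured. Relative to compound 1 it carries 2-methyl-1,3-thiazol-4-yl in place of 2-methoxyethyl on a saturated chain carbon bound to an aromatic nitrogen. Among the compounds with values here, the one step that bears on this is the exchange of 2-methoxyethyl for an aromatic ring, which gave a 7.7-fold lower number from compound 1 to compound 2 (0.88 log units; beyond the scatter); the 2-methyl-1,3-thiazol-4-yl entering here is likewise an aromatic ring in place of that chain, so a lowering step of roughly that size is expected, a 4.6-fold lower number from compound 1 to compound 3 (0.66 log units; beyond the scatter). Compound 3 is therefore estimated at 5 ug/mL, within 2 ug/mL to 15 ug/mL.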

Compound 3, solubility: 8 ug/mL
Beside the measured number, compound 3's estimate is 1.6-fold (0.20 log units) below it, and the stated range covers the measured number.
By their numbers in this assay, from the lowest: compound 2; then compound 3; then compound 1.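

In this assay the 2-methyl-1,3-thiazol-4-yl in place of 2-methoxyethyl, on a saturated chain carbon bound to an aromatic nitrogen, gives a 2.9-fold lower number from compound 1 to compound 3 (0.46 log units; beyond the scatter), so a second aromatic ring also falls short of the chain. The two rings do not read alike at this position: 2-methyl-1,3-thiazol-4-yl in place of 5-methylpyridin-2-yl gives a 2.7-fold higher number from compound 2 to compound 3 (0.43 log units; beyond the scatter), so the identity of the ring counts here, not only its presence. Nothing at hand accounts for this gap.

As far as these compounds go, how an amine or a carboxylic acid at this position would read in this assay remains open. So does whether a longer ether chain would stand above compound 1.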